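Swapping the methoxycarbonyl of compound 3 for a ring

This account rests on a few compounds, and the source may have more. Where it says the series, first, only, none or still open, it means among the compounds named here.

Three compounds have numbers in a functional assay on blood (Homo sapiens) for inhibition; on this read-out higher numbers stand for weaker inhibition and lower numbers for stronger inhibition. Compound 1 `O=C(Nc1cccnc1)Oc1ccc(OCc2nc3ccccc3s2)cc1C1(c2ccccc2)CC2CCC1C2` gives 37 nM; 86 nM; 33 nM (3 entries) across its repeated entries. Compound 2 `COc1ccc(OCc2ccc3ccccc3n2)cc1C1(c2ccccc2)CC2CCC1C2` gives 1100 nM and compound 3 `COC(=O)COc1ccc(OCc2ccc3ccccc3n2)cc1C1(c2ccccc2)CCCC1` gives 890 nM. These last two values lie within the scatter of each other, and both stand well above the entries of compound 1.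

Compound 4 `C1=CC(COc2ccc(OCc3ccc4ccccc4n3)cc2C2(c3ccccc3)CCCC2)=CNC1` has not yet been measured. It differs from compound 3 at a single place: a group of 6 heavy atoms (5 carbon, 1 nitrogen; one six-membered non-aromatic ring with 1 hetero atom) in place of a group of 4 heavy atoms (2 carbon, 2 oxygen; no ring), on a saturated chain carbon bound to an oxygen on an aromatic ring. The methoxycarbonyl leaves a saturated chain carbon bound to an oxygen on an aromatic ring, and a group with one six-membered non-aromatic ring with 1 hetero atom enters there.

Within the data shown here, no measured pair shows a change of this kind, so any forecast remains loose. In this assay no shift beyond the scatter is expected, and the expectation starts from compound 3 at 890 nM. The estimated move is a 1.1-fold lower number from compound 3 to compound 4 (0.05 log units; within the scatter). For compound 4 the expected value is 800 nM, with an estimated range from 200 nM to 3000 nM.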

Compound 4, half-maximal inhibitory concentration: 200 nM
For compound 4 the middle estimate is 4.0-fold (0.60 log units) above the measured one; measured number inside the range.
By their numbers in this assay, from the lowest: compound 4; then compounds 3 and 2 (each within the scatter of the next).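

At the saturated chain carbon bound to an oxygen on an aromatic ring, the group carried there makes a measurable difference: in this assay, the six-membered non-aromatic ring with 1 hetero atom in place of the methoxycarbonyl gives a 4.5-fold lower number from compound 3 to compound 4 (0.65 log units; beyond the scatter). Among these compounds, the earlier compounds offered no step at all, so this is the first sign that a change at this place can move the number beyond the scatter. The step is modest and rests on a single entry for each of the two compounds, while repeated entries of one compound can spread: the several entries of compound 1 in this assay, 37 nM; 86 nM; 33 nM (3 entries)

On these data alone, whether the ring as a whole or its nitrogen accounts for the step stays open, as does how a carboxylic acid or a simple amine would read at this place. The compounds shown also leave open whether the same change would give a similar step on the core of compound 2.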